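Shortening the linker to the benzamide in compound 2's series

The compounds below may be only part of what the source reports. "The series", "measured", "known", "first", "only" and "open" are said of these compounds alone.

Two members of this series carry a measured number. Compound 1 `CN1CCN(c2nc(Cl)nc3c2ncn3Cc2ccc(C(=O)Nc3ccccc3N)cc2)CC1` gives 72.8% in a functional assay on HCT-116 cells (Homo sapiens) for antiproliferative activity, read by CCK-8 assay, with a stated time of 72 h, tested at 8 uM; on this read-out lower numbers stand for a weaker effect and higher numbers for a stronger effect at the one concentration tested. Compound 2 `Nc1ccccc1NC(=O)/C=C/c1ccc(Cn2cnc3c(NCc4ccccc4)nc(Cl)nc32)cc1` gives 17.4% in this assay, the lowest of the two values shown, with compound 1 standing beyond the scatter above it. For the measured compounds named here, no step between these two is counted here, as they differ in more than one place; only their two values can be set side by side.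

Compound 3 `Nc1ccccc1NC(=O)c1ccc(Cn2cnc3c(NCc4ccccc4)nc(Cl)nc32)cc1` is the next member to be measured. It differs from compound 2 in one place: (2-aminophenyl)carbamoyl in place of 2-((2-aminophenyl)carbamoyl)ethenyl on an aromatic carbon

Going by the values given here, no measured step covers this change. The expected step of a number 24.6 percentage points higher from compound 2 to compound 3 (beyond the scatter) in this assay is upward and beyond the scatter, though uncertain in size. Compound 3 is estimated at 42% in this assay, within a range from 18% to 70%.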

Compound 3, a percentage reported as inhibition, at one concentration (the size of the read-out at that concentration, not a potency): 78.4%
Beside the measured number, compound 3's estimate is 36.4 percentage points below it, outside the stated range (above it).
By their numbers in this assay, from the lowest: compound 2; then compounds 1 and 3 (each within the scatter of the next).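

In this assay, (2-aminophenyl)carbamoyl in place of 2-((2-aminophenyl)carbamoyl)ethenyl, on the aromatic carbon para to a large group, gives a number 61 percentage points higher from compound 2 to compound 3 (beyond the scatter), so this position responds strongly to the change when benzylamino is held constant. With (2-aminophenyl)carbamoyl held constant, benzylamino in place of 4-methylpiperazin-1-yl gives a number 5.6 percentage points higher from compound 1 to compound 3 (within the scatter), so this assay does not separate those two groups on the shared core. No measurement in hand explains either step.

Going by these compounds, it remains open whether the step from 2-((2-aminophenyl)carbamoyl)ethenyl to (2-aminophenyl)carbamoyl keeps its size with 4-methylpiperazin-1-yl on the core. Also open, on these data alone, is how the saturated 2-((2-aminophenyl)carbamoyl)ethyl chain, or a morpholine in place of benzylamino, would read.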